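A chain-ended hydrazide replaces the pyrazole on the acyl group

The compounds below may be only part of what the source reports. "The series", "measured", "known", "first", "only" and "open" are said of these compounds alone.

Two measured analogues share a dihydropyridine core and differ only in the group on the carbonyl carbon of the aryloxyacetyl arm. Compound 1 `CCOC(=O)C1=C(C)NC(C)=C(C(=O)OCC)C1c1ccc(OCC(=O)NNC(=O)c2sccc2Cl)cc1` gives 39.7% in a functional assay on the whole organism (strain Wistar) for inhibition, with Rattus norvegicus as the target, read by paw edema, with stated times of 30 min and 1 h, at a dose of 20 mg/kg; on this read-out higher numbers stand for more inhibition at the one dose given (going by the name of the read-out) and lower numbers for less inhibition. Compound 2 `CCOC(=O)C1=C(C)NC(C)=C(C(=O)OCC)C1c1ccc(OCC(=O)n2nc(C)cc2C)cc1` gives 32.7% in this assay, the lower of the two numbers, but the step of a number 7 percentage points lower from compound 1 to compound 2 (within the scatter) shows that the two values cannot be told apart. Compound 3 `CCOC(=O)C1=C(C)NC(C)=C(C(=O)OCC)C1c1ccc(OCC(=O)NNC(=O)CCC(=O)O)cc1` is not yet measured. It differs from compound 2 by a group of 9 heavy atoms (4 carbon, 2 nitrogen, 3 oxygen; no ring) in place of a group of 7 heavy atoms (5 carbon, 2 nitrogen; one five-membered aromatic ring with 2 hetero atoms), on a carbonyl carbon. Going by the values given here, the only step that bears on this change is the one from compound 1 to compound 2, which exchanged a group at the same carbonyl carbon and stayed within the scatter; on that evidence compound 3 is expected to give 35%, within 18% to 52%. The step of a number 2.3 percentage points higher from compound 2 to compound 3 (within the scatter) is therefore estimated to be no more than the scatter, in no firm direction.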

Compound 3, a percentage reported as inhibition, in the whole organism at one dose (the size of the read-out at that dose, not a potency): 43%
For compound 3 the middle estimate is 8 percentage points below the measured one; the range from low to high includes it.
By their numbers in this assay, from the lowest: compounds 2, 1 and 3 (each within the scatter of the next, the first and the last beyond it).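

Going by these compounds alone, at this carbonyl carbon, the open chain of compound 3 gives the first step beyond the scatter in this assay: replacing the 3,5-dimethyl-1H-pyrazol-1-yl group gives a number 10.3 percentage points higher from compound 2 to compound 3 (beyond the scatter), so the group here can shift the read-out, if only modestly. Exchanging 3-chlorothiophen-2-yl for 2-carboxyethyl on the same hydrazide gives a number 3.3 percentage points higher from compound 1 to compound 3 (within the scatter), which shows that the two chain ends cannot be told apart and that the ring on compound 1 is not needed to reach this level of inhibition. Nothing measured here gives a reason for either step.

Going by these compounds, it remains open whether the hydrazide link or the carboxylic acid at the chain end accounts for the step from the pyrazole. An ethyl ester, an amine or a longer chain in place of that acid could help separate the two.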